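This account rests on a few compounds, and the source may have more. Where it says the series, first, only, none or still open, it means among the compounds named here.

Three compounds share one core and differ only in the aromatic group attached to the double-bonded chain carbon. Compound 1 `COc1cccc(/C=C2\SC(=O)N(Cc3ccc(C(=O)O)cc3)C2=O)c1` carries a 3-methoxyphenyl there, compound 2 `O=C(O)c1ccc(CN2C(=O)S/C(=C\c3cccnc3)C2=O)cc1` a pyridin-3-yl, and compound 3 `O=C(O)c1ccc(CN2C(=O)S/C(=C\c3ccccc3)C2=O)cc1` a plain phenyl. In a functional assay on HT-29 cells (Homo sapiens) for cytotoxicity, read by MTT assay, with a stated time of 24 h (a higher number here means a weaker inhibitor, a lower number a stronger inhibitor), compound 1 gives 48000 nM, compound 2 gives 90000 nM, and compound 3 gives 88000 nM. Compound 2 has the highest of these three numbers, yet its gap to compound 3 is a 1.0-fold lower number from compound 2 to compound 3 (0.01 log units; within the scatter) and the step leading up to it is a 1.9-fold higher number from compound 1 to compound 2 (0.27 log units; within the scatter), so the three values cannot be told apart on this evidence.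

Compound 4 `O=C(O)c1ccc(CN2C(=O)S/C(=C\c3ccc(F)cc3)C2=O)cc1` has not yet been measured. It differs from compound 2 as follows: 4-fluorophenyl in place of pyridin-3-yl on a double-bonded chain carbon bound to a double-bonded ring carbon Two earlier steps bear on this change. Swapping pyridin-3-yl for phenyl gave a 1.0-fold lower number from compound 2 to compound 3 (0.01 log units; within the scatter), and removing the methoxy from the phenyl gave a 1.8-fold higher number from compound 1 to compound 3 (0.26 log units; within the scatter); both stayed within the scatter. Since 4-fluorophenyl is again a six-membered aromatic ring of carbon only with a single small substituent, no step beyond the scatter is expected in this assay, in either direction. Compound 4 is therefore expected to give about 80000 nM, with a plausible range from 40000 nM to 160000 nM, which would correspond to an expected step of a 1.1-fold lower number from compound 2 to compound 4 (0.05 log units; within the scatter).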

Compound 4, half-maximal inhibitory concentration: 32000 nM
The estimate for compound 4 lay 2.5-fold (0.40 log units) above the measured number; the whole stated range lies above it.
By their numbers in this assay, from the lowest: compounds 4, 1, 3 and 2 (each within the scatter of the next, the first and the last beyond it).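

Until now, no change at this place on the double-bonded chain carbon had moved the number in this assay beyond the scatter, so the position had looked indifferent to what sits there. Compound 4 changes that picture: a single fluoro on the phenyl ring is enough to give a step beyond the scatter (a 2.8-fold lower number from compound 3 to compound 4 (0.44 log units; beyond the scatter)), and replacing pyridin-3-yl with 4-fluorophenyl gives a step of much the same size (a 2.8-fold lower number from compound 2 to compound 4 (0.45 log units; beyond the scatter)), though both steps are modest. The 3-methoxyphenyl compound still cannot be separated from the new compound (a 1.5-fold lower number from compound 1 to compound 4 (0.18 log units; within the scatter)), so 4-fluorophenyl stands apart from phenyl and pyridin-3-yl but not from every group tried here, and nothing measured here explains why the fluoro makes this difference.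

As far as these compounds go, it stays open whether this step belongs to fluorine itself or would also appear with other single groups on the phenyl ring, such as a 4-chlorophenyl, a 4-aminophenyl or a 4-carboxyphenyl. A 2-fluorophenyl or 3-fluorophenyl would show whether the place of the fluoro on the ring matters as well.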